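The source may report more compounds than this note shows. Statements on the series, on what has been measured and on what is new or still open speak of the compounds shown alone.

Series on the shared core of compound 3 `Cc1ccc(OCC(=O)N2CCN(c3ccc(C(F)(F)F)cc3[C@@H](N)CC(C)C)CC2)cc1`. In an assay on HEK293 cells for displacement of a labelled ligand from Melanocortin receptor 4 (Homo sapiens) (a higher number here means a weaker inhibitor, a lower number a stronger inhibitor), compound 3 gives 4400 nM, the highest of the three numbers: compound 1 `COc1cc(CC(C)C(=O)N2CCN(c3ccc(C(F)(F)F)cc3[C@@H](N)CC(C)C)CC2)ccc1Cl` gives 230 nM and compound 2 `CC(C)C[C@H](N)c1cc(C(F)(F)F)ccc1N1CCN(C(=O)[C@H](C)Cc2ccc(Cl)cc2)CC1` gives 31 nM. All measured steps alter the group on the carbonyl carbon: a 7.4-fold lower number from compound 1 to compound 2 (0.87 log units; beyond the scatter), a 19-fold higher number from compound 1 to compound 3 (1.28 log units; beyond the scatter), a 140-fold higher number from compound 2 to compound 3 (2.15 log units; beyond the scatter). Compound 4 `Cc1ccc(OCC(=O)N2CCN(c3ccc(C(F)(F)F)cc3[C@@H](N)CC(C)C)CC2)c(C)c1` differs from compound 3 by methyl in place of hydrogen on an aromatic carbon. Among the measured compounds shown here, no measured step touches the (4-methylphenoxy)methyl group itself, so the data hold nothing on this added methyl; the expectation in this assay is a step no larger than the scatter, in either direction, with the number staying near that of compound 3. Compound 4 is therefore estimated at 3500 nM, range 1400 nM to 9000 nM, which means a 1.3-fold lower number from compound 3 to compound 4 (0.10 log units; within the scatter).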

Compound 4, inhibition constant: 4000 nM
Beside the measured number, compound 4's estimate is 1.1-fold (0.06 log units) below it; the measured number falls inside the stated range.
By their numbers in this assay, from the lowest: compound 2; then compound 1; then compounds 4 and 3 (each within the scatter of the next).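

In this assay the change from 4-methylphenoxy to 2,4-dimethylphenoxy gives a 1.1-fold lower number from compound 3 to compound 4 (0.04 log units; within the scatter) and so shows that this aromatic carbon, the first position probed on this ring, accepts a methyl with no change beyond the scatter. Against the 1-(4-chlorobenzyl)ethyl and 1-(4-chloro-3-methoxybenzyl)ethyl groups on the carbonyl carbon, the (2,4-dimethylphenoxy)methyl group shows a 130-fold higher number from compound 2 to compound 4 (2.11 log units; beyond the scatter) and a 17-fold higher number from compound 1 to compound 4 (1.24 log units; beyond the scatter) and thus keeps the large gap already seen with compound 3. No evidence on hand bears on this result.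

On these data alone, whether a chlorine, a methoxy group or an amine on this same aromatic carbon would also leave the number unmoved remains open. Also open, as far as these compounds go, is whether a methyl here would matter on a chain carrying the 1-(4-chlorobenzyl)ethyl group.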